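Longer alkynyl chain in place of vinyl on a nucleoside base

This account rests on a few compounds, and the source may have more. Where it says the series, first, only, none or still open, it means among the compounds named here.

Compound 1: `C=Cc1cn([C@H]2C[C@H](O)[C@@H](CO)O2)c(=O)[nH]c1=O` — 14200 nM
Compound 2: `C[C@H](O)C1CC(CCn2nnc3c(N)ncnc32)C1(C)C` — > 200000 nM
Compound 3: `O=c1ccn([C@@H]2CCC[C@H]2CO)c(=O)[nH]1` — > 200000 nM

In an ADME assay on L1210/0 cells (Mus musculus) for cytotoxicity, with a stated time of 48 h (on this read-out lower numbers stand for stronger inhibition and higher numbers for weaker inhibition), compound 1 gives 14200 nM. Among the measured compounds shown here, this is the only number in the set. For compound 2 the value > 200000 nM is a limit of this assay, not a number. For compound 3 the value > 200000 nM is likewise a limit. For the measured compounds named here, two of the three values therefore sit at the limit of > 200000 nM in this assay, at which 2 of the 3 values shown sit, so compound 1 stands alone as the one compound with a measurable number, and no step between measured compounds can be drawn from it.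

The unmeasured compound 4, `CCCCCC#Cc1cn([C@H]2C[C@H](O)[C@@H](CO)O2)c(=O)[nH]c1=O`, shares the core of compound 1 and differs from it in one place: hept-1-yn-1-yl in place of vinyl on an aromatic carbon. The hept-1-yn-1-yl group sits on the aromatic carbon where the vinyl group stood, two atoms from the ring nitrogen.

Going by the values given here, with no measured step on this core, the expectation rests on compound 1 alone. The step from compound 1 to compound 4 is expected to be modest and, if anything, toward weaker inhibition, a 2.1-fold higher number from compound 1 to compound 4 (0.32 log units; beyond the scatter), and could well lie within the scatter. Compound 4 is therefore estimated at 30000 nM, with a range from 5000 nM to 200000 nM, and a real chance that only a limit is reported.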

Compound 4, half-maximal inhibitory concentration: > 200000 nM
Compound 4: no number, only a limit; the forecaster's own chance of this, stated with the estimate: 25%; middle value at least 6.6-fold (0.82 log units) from the limit.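

In this assay, the aromatic carbon two atoms from the ring nitrogen proves sensitive to what it carries: hept-1-yn-1-yl in place of vinyl gives an at least 14-fold higher number from compound 1 to compound 4 (1.14 log units; beyond the scatter). The measurable inhibition of compound 1 is therefore not kept by every carbon group at this place, even though the change adds no hydrogen-bond donors or acceptors. The value for compound 4 is a limit and not a number, so the step shows only a minimum size, and this compound joins most of the set at that same limit: the limit of > 200000 nM in this assay, at which 3 of the 4 values shown sit.

One step cannot tell whether the longer chain or the triple bond matters more, since the two change together here. Ethynyl would carry the triple bond on a short group and heptyl the long chain without a triple bond, so these two groups at the same place would leave open how much of the change each feature accounts for.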